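Orexin-1 antagonists: amine substituent swap on shared core

The source may hold more compounds than are shown below. What is called first, only, known or untested is meant among the compounds shown, and "the series" means these compounds.

Measured so far:
Compound 1 `Cc1nc(C(=O)N2CC3(CC3)C[C@H]2CNc2ncc(Cl)cn2)c(-c2ccccc2)s1` gives 6.8 in a functional assay on CHO cells for antagonist activity at Orexin/Hypocretin receptor type 1 (Homo sapiens), read by FLIPR and calcium flux; on this read-out higher numbers stand for higher potency (the scale is a negative logarithm) and lower numbers for lower potency.
Compound 2 `Cc1ccc(-n2nccn2)c(C(=O)N2CC3(CC3)C[C@H]2CNc2cccc(C)n2)c1` gives 7.1 in this assay.

Compound 1 holds the lower of the two values shown, but compound 2 lies within the scatter of it, so no order between the two is claimed. Compound 3 `Cc1nc(C(=O)N2CC3(CC3)C[C@H]2CNc2ccc(C(F)(F)F)cn2)c(-c2ccccc2)s1` differs from compound 1 in one place: 5-(trifluoromethyl)pyridin-2-yl in place of 5-chloropyrimidin-2-yl on an amine nitrogen. The entering group sits on an amine nitrogen whose other neighbour is a saturated chain carbon. Going by the values given here, no measured pair shows this change, so its size is unknown. The change is expected to shift potency by a number 0.10 log units higher from compound 1 to compound 3 (within the scatter), nothing beyond the scatter in either direction. Compound 3 is estimated at 6.9, within 6.3 to 7.5.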

Compound 3, negative logarithm of the antagonist equilibrium constant: 8.4
The estimate for compound 3 lay 1.50 log units below the measured number, outside the stated range (above it).
By their numbers in this assay, from the lowest: compounds 1 and 2 (each within the scatter of the next); then compound 3.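

In this assay, 5-(trifluoromethyl)pyridin-2-yl in place of 5-chloropyrimidin-2-yl on the amine nitrogen gives a number 1.60 log units higher from compound 1 to compound 3 (beyond the scatter). The group on this amine nitrogen can therefore move potency strongly, which compound 1 and compound 2 could not show, since they differ in more than one place. Nothing available accounts for the size of this step.

As far as these compounds go, the change alters the ring and its substituent together, so the share of each remains open. A 5-chloropyridin-2-yl group on the same amine nitrogen would separate the two.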